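This account rests on a few compounds, and the source may have more. Where it says the series, first, only, none or still open, it means among the compounds named here.

Compound 1 `CNC(=O)c1cc(Oc2ccc(NC(=O)c3cc(-c4ccc(OC)cc4)ncn3)cc2F)ccn1` gives 46200 nM in a functional assay on MCF7 cells (Homo sapiens) for cytotoxicity, read by MTT assay, with a stated time of 72 h; a higher number here means a weaker inhibitor, a lower number a stronger inhibitor.
Compound 2 `CNC(=O)c1cc(Oc2ccc(NC(=O)c3nccc(-c4ccc([N+](=O)[O-])cc4)n3)cc2)ccn1` gives only a limit of the assay, > 100000 nM, in this assay.
Compound 3 `CNC(=O)c1cc(Oc2ccc(NC(=O)c3nccc(-c4ccc(C)cc4)n3)cc2)ccn1` gives 44300 nM in this assay.

Compound 1 and compound 3 sit within the usual scatter of each other, while compound 2 stands at the limit (the limit of > 100000 nM in this assay, at which 1 of the 3 values shown sits). For the measured compounds named here, the only measured step, an at least 2.2-fold lower number from compound 2 to compound 3 (0.35 log units; beyond the scatter), shows that exchanging one group on the outer aromatic ring can shift the number at least modestly.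

Compound 4 `CNC(=O)c1cc(Oc2ccc(NC(=O)c3cc(-c4ccccc4)ncn3)cc2F)ccn1` differs from compound 1 by hydrogen in place of methoxy on an aromatic carbon. Going by the values given here, no measured pair among the compounds shows exactly this exchange, so the expectation rests on the one step that touches the same outer ring: it was at least modest, yet it involved a charged nitro group, and the change here is a far smaller one. A shift within the usual scatter, in either direction, seems the most likely outcome.

Compound 4 is therefore expected to give about 50000 nM, with a range from 20000 nM to 120000 nM. The expected step is a 1.1-fold higher number from compound 1 to compound 4 (0.03 log units; within the scatter), within the usual scatter.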

Compound 4, half-maximal inhibitory concentration: 32400 nM
Compound 4: middle estimate off by 1.5-fold (0.19 log units), on the high side; the range from low to high includes it.
By their numbers in this assay, from the lowest: compounds 4, 3 and 1 (each within the scatter of the next). At a limit, above all of these: compound 2.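

Taking the methoxy off the outer ring, so that 4-methoxyphenyl becomes phenyl, gives a 1.4-fold lower number from compound 1 to compound 4 (0.15 log units; within the scatter) in this assay, which means compound 1 and compound 4 cannot be told apart here. Unlike the earlier step from nitro to methyl, this exchange leaves the aromatic carbon with no group beyond hydrogen, and the activity seen in compound 1 is kept without the methoxy. No measurement shown here speaks to why the two compounds read alike.

As far as these compounds go, whether an amine, a carboxylic acid or a longer chain such as butoxy at the same place would move the number beyond the scatter stays open. So does whether this exchange would read the same on the core of compound 3, which differs from compound 1 in more than one place.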